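The source may report more compounds than this note shows. Statements on the series, on what has been measured and on what is new or still open speak of the compounds shown alone.

Measured compounds:
Compound 1 `COC(=O)[C@@]1(C)CCC=C2[C@@H]1CC[C@@H](C)[C@]2(C)Cc1c[nH]c2c(Cl)cccc12`: 24000 nM
Compound 2 `COC(=O)[C@@]1(C)CC[C@@H]2C3=C1CC[C@@H](C)[C@]3(C)C[C@@H]1c3cc(C)ccc3N[C@H]21`: 23000 nM

Both compounds were tested in a functional assay on T47D cells (Homo sapiens) for inhibition, read by sulforhodamine B assay, with a stated time of 48 h; on this read-out higher numbers stand for weaker inhibition of growth and lower numbers for stronger inhibition of growth. Compound 2 gives 23000 nM and compound 1 gives 24000 nM, and the gap between these two numbers lies within the usual scatter of repeated measurements, so neither compound can be set apart from the other. Within the data shown here, no pair of measured compounds differs in just one place, so this set contains no single-change step from which the effect of one substitution could be read.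

Compound 3 `COC(=O)[C@@]1(C)CC[C@@H]2C3=C1CC[C@@H](C)[C@]3(C)C[C@@H]1c3cc(Cl)ccc3N[C@H]21` differs from compound 2 by chloro in place of methyl on an aromatic carbon. Nothing in the measured data points to a direction for this change, so a step of about a 1.2-fold lower number from compound 2 to compound 3 (0.06 log units; within the scatter) is expected, a size that stays inside the scatter. Compound 3 is therefore estimated at 20000 nM, with a range from 7000 nM to 60000 nM.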

Compound 3, concentration for 50% growth inhibition: 28000 nM
The estimate for compound 3 lay 1.4-fold (0.15 log units) below the measured number; low and high end bracket the measured number.
By their numbers in this assay, from the lowest: compounds 2, 1 and 3 (each within the scatter of the next).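

Among these compounds, this is the first single-change step in the set: chloro in place of methyl on an aromatic carbon gives a 1.2-fold higher number from compound 2 to compound 3 (0.09 log units; within the scatter) in this assay and so offers a direct comparison of the two groups. At this position, meta to a fused ring and para to a fused ring, the step stays within the usual scatter of repeated measurements, so methyl and chloro cannot be told apart by this read-out. No further measurement accompanies this result that could bear on it.

On these data alone, it remains open whether a different group on this aromatic carbon, such as an amine, a carboxylic acid or a longer chain, would move the number beyond the scatter. As far as these compounds go, it also remains open whether the same swap would give a similar result on another carbon of this ring.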